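A few compounds are considered here, and "the series" means these few. Any claim that something is new, unique, unknown or untested is made for them only; others in the source may bear on it.

Measured so far:
Compound 1, `CC(OC1=NCCN1)c1ccccc1`: 263 nM
Compound 2, `Cc1ccccc1C(C)OC1=NCCN1`: 269 nM

Both compounds were tested in an assay on CHO cells for displacement of a labelled ligand from Alpha-2C adrenergic receptor (Homo sapiens), read by scintillation counting, with a stated time of 30 min; on this read-out higher numbers stand for weaker inhibition and lower numbers for stronger inhibition. Among the measured compounds shown here, the only measured step, a 1.0-fold higher number from compound 1 to compound 2 (0.01 log units; within the scatter), shows that putting a methyl on the aromatic ring left the number where it was. Compound 2 therefore holds the higher of the two numbers, yet it sits within the scatter of compound 1, so no order between them can be read from this assay.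

Compound 3, `CCCc1ccccc1C(C)OC1=NCCN1`, differs from compound 2 by ethyl in place of hydrogen on a saturated chain carbon bound to an aromatic carbon. For the measured compounds named here, the step from compound 1 to compound 2 is the one measured change that bears on this, and it was flat. Going by the values given here, the new change is larger, however, and no measured pair tests a chain of this length on that carbon, so the expectation rests on a single flat step. The step from compound 2 to compound 3 is expected to be a 1.3-fold higher number from compound 2 to compound 3 (0.11 log units; within the scatter), at most a mild weakening. Compound 3 is estimated at 350 nM, with a range from 120 nM to 1000 nM.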

Compound 3, inhibition constant: 148 nM
Beside the measured number, compound 3's estimate is 2.4-fold (0.37 log units) above it; low and high end bracket the measured number.
By their numbers in this assay, from the lowest: compounds 3, 1 and 2 (each within the scatter of the next).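

In this assay, going from methyl to propyl on the same aromatic carbon gives a 1.8-fold lower number from compound 2 to compound 3 (0.26 log units; within the scatter), and the whole change from the unsubstituted ring gives a 1.8-fold lower number from compound 1 to compound 3 (0.25 log units; within the scatter). The earlier pair covered only a methyl, whereas these steps show that this position also accepts the longer propyl chain with every number staying within the scatter, so all three compounds remain unseparated. Nothing measured here speaks to how a propyl at this place acts on the receptor.

The compounds shown leave open whether a longer chain, such as hexyl, would finally move the number beyond the scatter. They also leave open what an amine or a carboxylic acid would do in place of the propyl.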